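Swapping the amide aryl group of compound 2

The compounds below may be only part of what the source reports. "The series", "measured", "known", "first", "only" and "open" are said of these compounds alone.

In a functional assay on A549 cells (Homo sapiens) for inhibition, read by CCK-8 assay, with a stated time of 72 h, tested at 1 uM (a lower number here means less inhibition of growth, a higher number more inhibition of growth at the concentration tested), compound 1 (`COC(=O)c1ccc(NC(=O)C2(C(=O)Nc3ccc(Nc4ncc5cc(C(=O)N(C)C)n(C6CCCC6)c5n4)cc3)CC2)cc1`) gives 77.1%. For the measured compounds named here, compound 2 (`CN(C)C(=O)c1cc2cnc(Nc3ccc(NC(=O)C4(C(=O)Nc5cccc(C#N)c5)CC4)cc3)nc2n1C1CCCC1`) gives 70.8%, within the scatter of compound 1, the only other compound measured so far. Compound 3 (`CN(C)C(=O)c1cc2cnc(Nc3ccc(NC(=O)C4(C(=O)Nc5ccc(O)cc5)CC4)cc3)nc2n1C1CCCC1`) has 4-hydroxyphenyl in place of 3-cyanophenyl on an amide-type nitrogen. Going by the values given here, one measured step bears on this change, as it exchanges the group at the same place: a number 6.3 percentage points lower from compound 1 to compound 2 (within the scatter). Among the compounds with values here, no measured compound yet carries 4-hydroxyphenyl, so this single step is a thin guide. Within the data shown here, with only that small step to go on, no change beyond the scatter is expected in this assay, and the estimated step is a number 2.8 percentage points lower from compound 2 to compound 3 (within the scatter). For compound 3 the expected value is 68%, with an estimated range of 52% to 82%.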

Compound 3, percent growth inhibition at one concentration: 93.6%
Estimate against measurement, compound 3: 25.6 percentage points below; the whole stated range lies below it.
By their numbers in this assay, from the lowest: compounds 2 and 1 (each within the scatter of the next); then compound 3.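

In this assay, the aryl group on the amide-type nitrogen now proves able to shift growth inhibition, which a number 6.3 percentage points lower from compound 1 to compound 2 (within the scatter) had not shown. 4-Hydroxyphenyl in place of 3-cyanophenyl gives a number 22.8 percentage points higher from compound 2 to compound 3 (beyond the scatter), and hydroxy in place of methoxycarbonyl on an aromatic carbon gives a number 16.5 percentage points higher from compound 1 to compound 3 (beyond the scatter). Compound 3 therefore stands above both other compounds, and at this place the hydroxy group, among the three groups shown, is the only change that moves the read-out beyond the scatter.

No evidence is available that accounts for this difference. On these data alone, whether an amine or a carboxylic acid in place of the hydroxy group would hold the same level in this assay remains open, as does whether a methoxy group would.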